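This account rests on a few compounds, and the source may have more. Where it says the series, first, only, none or still open, it means among the compounds named here.

Compound 1 `Cc1cc(S(N)(=O)=O)ccc1NC(=O)COc1ccc2ccccc2c1C(=O)c1cccc(Cl)c1` gives 37400 nM in an ADME assay on C8166 cells (Homo sapiens) for cytotoxicity, read by colorimetric assay and MTT assay; on this read-out higher numbers stand for lower toxicity in this test and lower numbers for higher toxicity in this test. Compound 2 `Cc1ccc(C)c(C(=O)c2c(OCC(=O)Nc3ccc(S(N)(=O)=O)cc3C)ccc3ccccc23)c1` gives 47500 nM, and compound 3 `Cc1ccc(C(=O)c2c(OCC(=O)Nc3ccc(S(N)(=O)=O)cc3C)ccc3ccccc23)c(C)c1` gives 25500 nM. Among these three numbers compound 1 has compound 2 nearest and compound 3 furthest, and every step among them stays within the scatter: a 1.3-fold higher number from compound 1 to compound 2 (0.10 log units; within the scatter), a 1.5-fold lower number from compound 1 to compound 3 (0.17 log units; within the scatter) and a 1.9-fold lower number from compound 2 to compound 3 (0.27 log units; within the scatter). Compound 4 `Cc1cc(S(N)(=O)=O)ccc1NC(=O)COc1ccc2cc(C#N)ccc2c1C(=O)c1cccc(Cl)c1` differs from compound 1 by cyano in place of hydrogen on an aromatic carbon. Within the data shown here, none of the measured steps touches this part of the shared core; all of them vary the aryl group on the carbonyl carbon, and all are within the scatter. Compound 4 is therefore expected to show a 1.1-fold lower number from compound 1 to compound 4 (0.03 log units; within the scatter), a step not beyond the scatter. The estimate for compound 4 is 35000 nM, ranging from 15000 nM to 80000 nM.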

Compound 4, half-maximal cytotoxic concentration: > 374000 nM
Compound 4: a limit, no number; the forecaster's own chance of this, stated with the estimate: 10%; middle value at least 10-fold (1.02 log units) away from the limit.
By their numbers in this assay, from the lowest: compounds 3, 1 and 2 (each within the scatter of the next). At a limit, above all of these: compound 4.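

In this assay, cyano in place of hydrogen on this aromatic carbon gives an at least 10-fold higher number from compound 1 to compound 4 (1.00 log units; beyond the scatter), the only step shown that lies beyond the scatter. The earlier compounds varied only the aryl group on the carbonyl carbon and stayed within the scatter, so this position of the shared core is the one place shown where a change moves the read-out clearly. Compound 4 stands at a limit and not at a number: the limit of > 374000 nM in this assay, at which 1 of the 4 values shown sits. On these data alone, the true size of the step stays open, as does whether an amine, a carboxylic acid or a methyl group on the same carbon would move the number likewise.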